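This account rests on a few compounds, and the source may have more. Where it says the series, first, only, none or still open, it means among the compounds named here.

Of the compounds shown here, two of a shared core have been measured in a functional assay on SNB-19 cells (Homo sapiens) for cytotoxicity, read by sulforhodamine B assay, with a stated time of 48 h, tested at 0.01 uM; a lower number here means a stronger effect, a higher number a weaker effect of the compound at the concentration tested. Compound 1, `COc1ccc(-c2cc(/C=C/C(=O)c3ccc(N)cc3)[nH]n2)cc1`, carries an aminophenyl on its carbonyl carbon, and in this assay compound 1 gives 92%. Compound 2, `COc1cc(-c2cc(/C=C/C(=O)c3ccc(Cl)c(Cl)c3)[nH]n2)cc(OC)c1OC`, carries a 3,4-dichlorophenyl on that carbonyl carbon and a trimethoxyphenyl on the core, and in this assay compound 2 gives 100%. These two numbers lie within the usual scatter of each other, so at this low concentration neither compound shows a clear effect on the cells, and compound 2 cannot be set apart from compound 1 on these data.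

Compound 3, `COc1cc(-c2cc(/C=C/C(=O)c3ccc(F)c(F)c3)[nH]n2)cc(OC)c1OC`, is the next compound to be measured. It differs from compound 2 in one place: 3,4-difluorophenyl in place of 3,4-dichlorophenyl on a carbonyl carbon. Going by the values given here, no step between two measured compounds of this set has been recorded, so nothing here tells how large a change such a swap brings. Since both measured compounds sit near the top of the percentage scale, the step of a number 2 percentage points lower from compound 2 to compound 3 (within the scatter) is expected to stay within the scatter. For compound 3 in this assay the estimate is 98%, with a range from 85% to 110%.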

Compound 3, a percentage reported as activity, at one concentration (the size of the read-out at that concentration, not a potency): 89%
Estimate against measurement, compound 3: 9 percentage points above, within the range that was stated.
By their numbers in this assay, from the lowest: compounds 3, 1 and 2 (each within the scatter of the next, the first and the last beyond it).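

In this assay, placing 3,4-difluorophenyl instead of 3,4-dichlorophenyl on the carbonyl carbon gives a number 11 percentage points lower from compound 2 to compound 3 (beyond the scatter). Going by these compounds alone, this is the first single change in the set that can be read, and it shows that the group at this position can alter the read-out even at this low concentration. A lower number means a stronger effect, so compound 3 has the stronger effect of this pair, but the step is modest and compound 3, at 89%, still sits high on the percentage scale. No measurement is available to explain what lies behind this difference.

Within the data shown here, with only this one pair, it remains open whether the step reflects a wider trend at this position or belongs to these two groups alone. A plain phenyl, or a phenyl carrying a nitrile or a trifluoromethyl group, on the same carbonyl carbon would show whether the read-out can move further down the scale with the trimethoxyphenyl kept on the core.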